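Dimethylamino in Place of Acetamido on the Fused Core

The source may hold more compounds than are shown below. What is called first, only, known or untested is meant among the compounds shown, and "the series" means these compounds.

Compound 1, `CN1CCC[C@H]1[C@H]1COc2c(O)cccc2O1`: 1700 nM
Compound 2, `CC(=O)Nc1ccc2c(c1)O[C@@H]([C@@H]1CCCN1C)CO2`: 46000 nM
Compound 3, `CC(=O)Nc1ccc2c(c1)O[C@H]([C@@H]1CCCN1C)CO2`: 6500 nM

All three were measured in an assay on membranes from Cerebral cortex for displacement of a labelled ligand from Neuronal acetylcholine receptor; alpha4/beta2 (Rattus norvegicus), with a stated time of 5 min; a higher number here means a weaker inhibitor, a lower number a stronger inhibitor. Among the three numbers, compound 3 stands second highest: its nearest neighbour is compound 1, whose number is lower, and its furthest is compound 2, whose number is higher. Among the measured compounds shown here, the only step between compounds differing in a single place is a 7.1-fold lower number from compound 2 to compound 3 (0.85 log units; beyond the scatter), and it rests on (the fact that compounds 2 and 3 differ only in the configuration as drawn), a change of configuration alone.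

Compound 4, `CN(C)c1ccc2c(c1)O[C@H]([C@@H]1CCCN1C)CO2`, follows from compound 3 by dimethylamino in place of acetamido on an aromatic carbon. For the measured compounds named here, no measured step bears on a substituent exchange of this kind: the one known step concerns configuration only, and the aromatic substituent otherwise varies only between compound 1 and compounds 2 and 3, where the stereochemistry changes as well. Compound 4 is therefore expected to show a step of a 1.3-fold lower number from compound 3 to compound 4 (0.11 log units; within the scatter) in this assay, not beyond the scatter. Compound 4 is estimated at 5000 nM, with a range from 1200 nM to 20000 nM.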

Compound 4, inhibition constant: 147000 nM
Beside the measured number, compound 4's estimate is 29-fold (1.47 log units) below it; the whole stated range lies below it.
By their numbers in this assay, from the lowest: compound 1; then compound 3; then compound 2; then compound 4.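

Exchanging acetamido for dimethylamino on the aromatic carbon gives, in this assay, a 23-fold higher number from compound 3 to compound 4 (1.35 log units; beyond the scatter), a large step where the only earlier one, a 7.1-fold lower number from compound 2 to compound 3 (0.85 log units; beyond the scatter), was modest. The group at this place of the shared core therefore weighs heavily on the number, at least with the configuration of compound 3, and the exchange takes away the hydrogen-bond donor that acetamido carries, since dimethylamino has none. Nothing known here bears on why the number rises with this exchange.

The compounds shown leave open whether a primary amine or a methoxy group at this place would stand nearer to compound 3 or to compound 4. They also leave open whether the same exchange would give a step of like size with the configuration of compound 2.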